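Replacing the benzyl group of compound 3 with methylpiperazine

A few compounds are considered here, and "the series" means these few. Any claim that something is new, unique, unknown or untested is made for them only; others in the source may bear on it.

Among the compounds with values here, compound 3 `CN(Cc1ccccc1)C(=O)CNC(=O)c1ccc(S(C)(=O)=O)c([N+](=O)[O-])c1` gives 39000 nM in an assay on isolated protein for inhibition of thyroid hormone receptor beta (Homo sapiens), read by fluorescence polarization (a higher number here means a weaker inhibitor, a lower number a stronger inhibitor), the higher of the two numbers measured so far. Compound 1 `CS(=O)(=O)c1ccc(C(=O)NCC(=O)N(Cc2ccccc2)Cc2ccccc2)cc1[N+](=O)[O-]` gives 3600 nM. Compound 2 `CS(=O)(=O)c1ccc(C(=O)NCC(=O)N2CCCCC2)cc1[N+](=O)[O-]` reaches only a limit of the assay, > 60000 nM, recorded as the limit of > 60000 nM in this assay, at which 1 of the 3 values shown sits, rather than as a number. Compound 4 `CN1CCN(C(=O)CNC(=O)c2ccc(S(C)(=O)=O)c([N+](=O)[O-])c2)CC1` carries 4-methylpiperazin-1-yl in place of benzyl(methyl)amino on a carbonyl carbon. Within the data shown here, two measured steps bear on this. In the step of an 11-fold higher number from compound 1 to compound 3 (1.03 log units; beyond the scatter), a phenyl was removed and binding weakened clearly. In the step of an at least 1.5-fold lower number from compound 2 to compound 3 (0.18 log units; that floor lies within the scatter), a saturated ring gave way to the benzyl(methyl)amino group, a shift too small to read. Trading the aromatic ring of compound 3 for a saturated ring is therefore expected to weaken binding again, an estimated step of a 2.1-fold higher number from compound 3 to compound 4 (0.31 log units; beyond the scatter), quite possibly beyond the assay limit. Compound 4 is expected to give 80000 nM, within 25000 nM to 250000 nM.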

Compound 4, half-maximal inhibitory concentration: > 60000 nM
Compound 4: a limit, no number; the forecaster's own chance of this, stated with the estimate: 65%; the middle value is on the limit's open side.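

In this assay compound 4 gives only a limit (> 60000 nM), so the step reads an at least 1.5-fold higher number from compound 3 to compound 4 (0.18 log units; that floor lies within the scatter) and on its own proves no loss. Putting a saturated ring with a second nitrogen in place of the benzyl(methyl)amino group brings back no measurable number, and the step between the two saturated rings cannot be read. Among these four compounds, only those carrying a benzyl group give numbers, while both saturated rings stay at the limit: the limit of > 60000 nM in this assay, at which 2 of the 4 values shown sit.

From the compounds shown here alone, how weak compounds 2 and 4 really are stays open, as does whether a cyclohexylmethyl group on the amide nitrogen could replace benzyl.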